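Adding a hydroxy group to the benzylidene ring of compound 1

A few compounds are considered here, and "the series" means these few. Any claim that something is new, unique, unknown or untested is made for them only; others in the source may bear on it.

Measured compounds:
compound 1 `COc1cc2c(cc1OC)C(=O)/C(=C/c1cccc(C)c1)C2`: 1800 nM
compound 2 `COc1cccc(/C=C2\Cc3cc(OC)c(OC)cc3C2=O)c1`: 12800 nM

In a functional assay on Jurkat cells (Homo sapiens) for antiproliferative activity, read by MTT assay (on this read-out higher numbers stand for weaker inhibition and lower numbers for stronger inhibition), compound 1 gives 1800 nM, the lowest of the two numbers. For the measured compounds named here, in the same this assay compound 2 gives 12800 nM, and the only measured step, a 7.1-fold higher number from compound 1 to compound 2 (0.85 log units; beyond the scatter), shows that swapping the methyl of compound 1 for a methoxy weakens the effect.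

Compound 3 `COc1cc2c(cc1OC)C(=O)/C(=C/c1ccc(O)c(C)c1)C2` is not yet measured. Compared with compound 1 the change is hydroxy in place of hydrogen on an aromatic carbon, placed on an aromatic carbon of a six-membered aromatic ring of carbon only, ortho to a methyl group and para to a large group. The methyl of compound 1 stays in place, so the measured step from compound 1 to compound 2 does not describe this change directly; it only shows that this ring is sensitive to substitution. Going by the values given here, no measured step bears on adding a hydroxy group here, so the expected change in this assay is uncertain, and a step of modest size in either direction, or none beyond the scatter, is plausible. Compound 3 is estimated at 1300 nM, with a range from 300 nM to 6000 nM, which means an expected step of a 1.4-fold lower number from compound 1 to compound 3 (0.14 log units; within the scatter).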

Compound 3, half-maximal inhibitory concentration: 1160 nM
Beside the measured number, compound 3's estimate is 1.1-fold (0.05 log units) above it, within the range that was stated.
By their numbers in this assay, from the lowest: compounds 3 and 1 (each within the scatter of the next); then compound 2.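

In this assay the hydroxy group, set ortho to a methyl group and para to a large group, gives a 1.6-fold lower number from compound 1 to compound 3 (0.19 log units; within the scatter) and so leaves compound 3 and compound 1 indistinguishable on this read-out. For the compounds shown here, the earlier pair, with a 7.1-fold higher number from compound 1 to compound 2 (0.85 log units; beyond the scatter) as its only step, showed a clear loss when a methoxy replaced the methyl, but it said nothing about adding a group elsewhere on the same ring, and this result shows that a hydroxy in place of hydrogen at this position is tolerated without a change beyond the scatter. Nothing measured here explains why the number stays in the same range when the hydroxy group enters.

The compounds shown leave open whether a larger or differently charged group at this position, such as an amine or a carboxylic acid, would be tolerated as well as the hydroxy. They also leave open whether the hydroxy would give a similar result without the methyl group on the ring, since the two appear together only in compound 3.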